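Swapping bromo for cyano: expected cytotoxicity of compound 4

A few compounds are considered here, and "the series" means these few. Any claim that something is new, unique, unknown or untested is made for them only; others in the source may bear on it.

Measured compounds:
compound 1 `COC(=O)c1ccc(NCc2cncn2Cc2ccccc2)cc1-c1ccccc1`: > 1000 nM
compound 2 `COC(=O)c1ccc(NCc2cncn2Cc2ccc(F)cc2)cc1-c1ccccc1`: "not determined" (no result reported)
compound 3 `COC(=O)c1ccc(NCc2cncn2Cc2ccc(Br)cc2)cc1-c1ccccc1`: > 10000 nM

In a toxicity assay on NIH3T3 cells (Mus musculus) for cytotoxicity, read by resazurin assay (on this read-out higher numbers stand for an effect only at larger amounts of compound and lower numbers for an effect already at smaller amounts), compound 1 gives > 1000 nM, which is a limit of the assay and not a number. For compound 2 the outcome is "not determined" (no result reported). Compound 3 gives > 10000 nM, again only a limit. The step that the two limits leave unreadable from compound 1 to compound 3 therefore has no readable size, since both ends rest on limits, the limit of > 1000 nM in this assay, at which 1 of the 3 values shown sits, and (the limit of > 10000 nM in this assay, at which 1 of the 3 values shown sits). Compound 3 thus stands at a limit; one further value is a limit, and one entry carries no number.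

Compound 4 `COC(=O)c1ccc(NCc2cncn2Cc2ccc(C#N)cc2)cc1-c1ccccc1` differs from compound 3 by cyano in place of bromo on an aromatic carbon. Among the compounds with values here, no measured step with a readable size bears on this change, so no step beyond the usual scatter is expected. The estimated step is a step that the limit leaves unreadable from compound 3 to compound 4. Compound 4 is expected to give 15000 nM, within a range from 5000 nM to 50000 nM.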

Compound 4, half-maximal effective concentration: > 10000 nM
Compound 4 was reported as a limit (the forecaster's own chance of this, stated with the estimate: 85%); the middle value is on the limit's open side.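

Within the data shown here, compound 1, compound 3 and compound 4 are all reported only as limits of the assay, and no step among them can be read. The compounds shown leave open whether hydrogen, bromo or cyano at this place changes cytotoxicity at all.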